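Methyl for bromo on a pyridine amide: a second look

A few compounds are considered here, and "the series" means these few. Any claim that something is new, unique, unknown or untested is made for them only; others in the source may bear on it.

Three amides of a shared core have been measured in a functional assay on the whole organism for inhibition, with Rattus norvegicus as the target, at a dose of 3 mg/kg by the oral route; a lower number here means a weaker effect, a higher number a stronger effect of the compound at the dose given. Compound 1 `Cc1cccc(C(=O)Nc2nn[nH]n2)n1` gives 46% there. Compound 2 `O=C(Nc1nn[nH]n1)c1cccc(Br)n1` gives 38% in this assay, and compound 3 `O=C(Nc1nn[nH]n1)c1cc(Br)ccn1` gives 34%. The two cores of compound 2 and compound 3 hold the same atoms joined differently; the difference between them is not broken down here. The values of compound 3 and compound 1 lie apart beyond the usual scatter, whereas compound 3 and compound 2 lie within it.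

One change has been seen once: from compound 2 to compound 1 the bromo gives way to a methyl (methyl in place of bromo on an aromatic carbon), and a number 8 percentage points higher from compound 2 to compound 1 (within the scatter).

Compound 4 `Cc1ccnc(C(=O)Nc2nn[nH]n2)c1` has not yet been measured. It follows from compound 3 by the same kind of change (methyl in place of bromo on an aromatic carbon), though the place differs: in compound 1 the methyl sits next to the ring nitrogen, in compound 4 it sits opposite the ring nitrogen. Going by the values given here, the expected step is a number 6 percentage points higher from compound 3 to compound 4 (within the scatter), because a number 8 percentage points higher from compound 2 to compound 1 (within the scatter) stayed within the scatter in the one earlier instance of this change. Compound 4 is therefore estimated at 40%, between 28% and 52%.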

Compound 4, a percentage reported as inhibition, in the whole organism at one dose (the size of the read-out at that dose, not a potency): 42%
The estimate for compound 4 lay 2 percentage points below the measured number; measured number inside the range.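

In this assay, methyl in place of bromo on an aromatic carbon again gives a number 8 percentage points higher from compound 3 to compound 4 (within the scatter). Set beside the earlier instance, the two steps agree: the same change on two cores in this assay, a number 8 percentage points higher (within the scatter) from compound 2 to compound 1 and a number 8 percentage points higher (within the scatter) from compound 3 to compound 4, 0 percentage points apart, within the scatter of two such steps. The change therefore carried over from one core to the other with its size unaltered, but each step lies within the scatter, so neither establishes a real difference between methyl and bromo on its own core, and two instances cannot show how the change would behave on any further core.

The compounds shown carry only methyl or bromo on the pyridine-type aromatic ring, so it remains open how an amine, a methoxy group, a carboxylic acid or a longer chain such as propyl would read at the same places. Also open, going by these compounds, is how these compounds would rank by potency, since the read-out gives the size of the effect at a single oral dose.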